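Dichlorophenyl sulfonyl in place of acetamidophenyl on a hydrazide

A few compounds are considered here, and "the series" means these few. Any claim that something is new, unique, unknown or untested is made for them only; others in the source may bear on it.

Measured compounds:
compound 1, `CC(=O)Nc1ccc(S(=O)(=O)NNC(=O)c2cccnc2Nc2ccc(Cl)cc2)cc1`: > 100000 nM
compound 2, `O=C(NNS(=O)(=O)c1ccc(F)cc1)c1cccnc1Nc1ccc(Cl)cc1Cl`: 27500 nM

Of the compounds shown here, two have been measured in a functional assay on RXF 393 cells (Homo sapiens) for antiproliferative activity; on this read-out lower numbers stand for stronger inhibition of growth and higher numbers for weaker inhibition of growth. Compound 1 gives only a limit of the assay, > 100000 nM, so no number is known for it. Compound 2 gives 27500 nM, a number within the range of the assay. Among the compounds with values here, no single step between these two compounds is defined, since they differ in more than one place. Of the two values, that of compound 1 sits at the limit of the assay (the limit of > 100000 nM in this assay, at which 1 of the 2 values shown sits). The value of compound 2 is read as a number.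

Compound 3, `O=C(NNS(=O)(=O)c1ccc(Cl)cc1Cl)c1cccnc1Nc1ccc(Cl)cc1`, has not yet been measured. It differs from compound 1 in one place: 2,4-dichlorophenyl in place of 4-acetamidophenyl on a sulfonyl sulfur. Since compound 1 stands at a limit, no step size in this assay can be drawn from the measured pair. The step of an at least 2.8-fold lower number from compound 1 to compound 3 (0.45 log units; beyond the scatter) is the one he expects, with the value of compound 3 estimated at 35000 nM, between 9000 nM and 100000 nM.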

Compound 3, concentration for total growth inhibition: 43700 nM
The estimate for compound 3 lay 1.2-fold (0.10 log units) below the measured number; the measured number falls inside the stated range.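

In this assay, within the data shown here, the exchange of 4-acetamidophenyl for 2,4-dichlorophenyl on a sulfonyl sulfur gives the first readable step at this position: an at least 2.2-fold lower number from compound 1 to compound 3 (0.35 log units; beyond the scatter). It shows that, with the rest of compound 1 unchanged, this one replacement is enough to bring the series from the edge of the assay to a number within its range. Compound 1 has only a limit of the assay, > 100000 nM, so the step gives a minimum and not a true size, because one end of the pair rests on that limit: the limit of > 100000 nM in this assay, at which 1 of the 3 values shown sits.

The change removes the acetamido group and adds two chlorines in a single exchange, so the compounds shown cannot say whether the lower number comes from losing the one or gaining the other. As far as these compounds go, how a plain phenyl, a 4-chlorophenyl, a 4-aminophenyl or a 4-carboxyphenyl on the same sulfonyl sulfur would compare remains open, as does whether the step would carry over to the core of compound 2, which differs from compound 1 and compound 3 in more than one place.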